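Replacing an acyl group by 2-aminoethyl on the ring nitrogen

The compounds below may be only part of what the source reports. "The series", "measured", "known", "first", "only" and "open" are said of these compounds alone.

Measured compounds:
compound 1, `CCCn1nc(-c2cccnc2)c2ccccc2c1=O`, 86%
compound 2, `CCOC(=O)CCCn1nc(-c2cccnc2)c2ccccc2c1=O`, 95%
compound 3, `O=C(c1cccs1)n1nc(-c2cccnc2)c2ccccc2c1=O`, 37%

The read-out throughout is an assay on isolated protein (Oryctolagus cuniculus) with Thromboxane-A synthase (Homo sapiens) as the target, tested at 1 uM; on this read-out lower numbers stand for less inhibition and higher numbers for more inhibition at the one concentration tested (going by the name of the read-out). Compound 3 stands lowest of the three numbers; compound 1 is the nearest to it, a number 49 percentage points lower from compound 1 to compound 3 (beyond the scatter), and compound 2 the furthest, a number 58 percentage points lower from compound 2 to compound 3 (beyond the scatter). Both steps are large and beyond the scatter, and in both a (thiophen-2-yl)carbonyl on the aromatic nitrogen replaced a saturated chain. Between the two chain-bearing compounds the change was small, a number 9 percentage points higher from compound 1 to compound 2 (within the scatter).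

Compound 4, `NCCn1nc(-c2cccnc2)c2ccccc2c1=O`, has not been measured. It differs from compound 3 in one place: 2-aminoethyl in place of (thiophen-2-yl)carbonyl on an aromatic nitrogen. Going by the values given here, this is the reverse direction of the two large steps seen so far, since a saturated chain again takes the place of the (thiophen-2-yl)carbonyl; the chain itself, carrying an amine, has no measured counterpart among compounds 1 and 2, so its own contribution is unknown.

Compound 4 is therefore expected to sit well above compound 3 in this assay, a step estimated at a number 43 percentage points higher from compound 3 to compound 4 (beyond the scatter). The estimate for compound 4 is 80%, within a range from 55% to 95%.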

Compound 4, a percentage reported as inhibition, at one concentration (the size of the read-out at that concentration, not a potency): 29%
Beside the measured number, compound 4's estimate is 51 percentage points above it; measured number below the stated range.
By their numbers in this assay, from the lowest: compounds 4 and 3 (each within the scatter of the next); then compounds 1 and 2 (each within the scatter of the next).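

In this assay, a saturated chain on the aromatic nitrogen does not carry the higher numbers by itself: amino in place of methyl, two bonds along the chain from that nitrogen, gives a number 57 percentage points lower from compound 1 to compound 4 (beyond the scatter) and amino in place of (ethoxycarbonyl)methyl gives a number 66 percentage points lower from compound 2 to compound 4 (beyond the scatter) in the same assay. Exchanging (thiophen-2-yl)carbonyl for 2-aminoethyl gives a number 8 percentage points lower from compound 3 to compound 4 (within the scatter) at this position, so these two very different groups leave the number in the same range, and what the chain carries matters here as much as the chain itself. No measurement at hand accounts for this outcome.

The compounds shown leave open whether the low number goes with the amine as such or with how far along the chain it stands, a question that a 3-aminopropyl group would address. They also leave open whether a 2-hydroxyethyl group or a dimethylamino group on the same chain would behave like the amino group or like the propyl group.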